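A few compounds are considered here, and "the series" means these few. Any claim that something is new, unique, unknown or untested is made for them only; others in the source may bear on it.

Measured compounds:
- compound 1 `O=c1[nH]cc(S(=O)(=O)Nc2ccccc2-c2cn(-c3ccccc3)nn2)c(=O)[nH]1` gives 6650 nM in a functional assay on OVCAR-3 cells (Homo sapiens) for antiproliferative activity, read by MTT assay, with a stated time of 24 h; a higher number here means a weaker inhibitor, a lower number a stronger inhibitor
- compound 2 `Cc1ccc(-n2cc(-c3ccccc3NS(=O)(=O)c3c[nH]c(=O)[nH]c3=O)nn2)cc1` gives 2190 nM in this assay

Going by the values given here, of these two numbers, compound 2 has the lower one; the only comparison available is the step of a 3.0-fold lower number from compound 1 to compound 2 (0.48 log units; beyond the scatter), which came from adding a methyl to an aromatic carbon of the shared core.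

Compound 3 `O=c1[nH]cc(S(=O)(=O)Nc2ccccc2-c2cn(-c3ccccc3F)nn2)c(=O)[nH]1` has not yet been measured. It differs from compound 2 by 2-fluorophenyl in place of 4-methylphenyl on an aromatic nitrogen. This change takes away the very methyl whose addition gave a 3.0-fold lower number from compound 1 to compound 2 (0.48 log units; beyond the scatter), and at the same time puts a fluorine on the ring at a different point. Among the compounds with values here, no measured step shows what the fluorine does, so the only guide is that loss of the methyl would be expected to pull the number back toward the value of compound 1.

Compound 3 is therefore expected to show a step of a 2.3-fold higher number from compound 2 to compound 3 (0.36 log units; beyond the scatter) in this assay, most likely a modest rise. The estimate for compound 3 is 5000 nM, with a plausible range from 1800 nM to 14000 nM.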

Compound 3, half-maximal inhibitory concentration: 15300 nM
Compound 3: the middle estimate sits 3.1-fold (0.49 log units) below what was measured, outside the stated range (above it).
By their numbers in this assay, from the lowest: compound 2; then compound 1; then compound 3.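

Fluorine on the phenyl ring carried by the aromatic nitrogen is not a neutral change: it gives a 2.3-fold higher number from compound 1 to compound 3 (0.36 log units; beyond the scatter) in this assay, whereas the methyl of 4-methylphenyl had lowered the number. Replacing 4-methylphenyl with 2-fluorophenyl brings these two opposite moves together and gives a 7.0-fold higher number from compound 2 to compound 3 (0.84 log units; beyond the scatter), the widest gap among the three compounds, so this ring position is more sensitive than the methyl step alone suggested. No supporting evidence is available to explain these differences.

The compounds shown do not separate the effect of the group from the effect of its place on the ring, as the methyl and the fluorine sit at different ring points. Also open, from the compounds shown here alone, is how an amine, a methoxy group or a carboxylic acid on this ring would behave.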